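This account rests on a few compounds, and the source may have more. Where it says the series, first, only, none or still open, it means among the compounds named here.

Compound 1 `Cc1cccc(-c2noc(C3CN(S(=O)(=O)c4ccc(Cl)cc4)C3)n2)c1`: 1100 nM
Compound 2 `O=C(C1CCC2(CCC2)CC1)N1CC(c2nc(-c3cccc(Cl)c3)no2)C1`: > 10000 nM

Of the compounds shown here, two have been measured in an assay on HEK293 cells for negative allosteric modulation of metabotropic glutamate receptor 5 (Homo sapiens), read by FLIPR; on this read-out higher numbers stand for weaker inhibition and lower numbers for stronger inhibition. Compound 1 `Cc1cccc(-c2noc(C3CN(S(=O)(=O)c4ccc(Cl)cc4)C3)n2)c1` gives 1100 nM. Compound 2 `O=C(C1CCC2(CCC2)CC1)N1CC(c2nc(-c3cccc(Cl)c3)no2)C1` is reported only as a limit, > 10000 nM, so no exact number stands for it. That limit is noted as the limit of > 10000 nM in this assay, at which 1 of the 2 values shown sits. Compound 3 `O=C(C1CCC1)N1CC(c2nc(-c3cccc(Cl)c3)no2)C1` has not yet been measured. It differs from compound 2 in one place: a group of 4 heavy atoms (4 carbon; one four-membered non-aromatic ring of carbon only) in place of a group of 9 heavy atoms (9 carbon; one four-membered non-aromatic ring of carbon only, one six-membered non-aromatic ring of carbon only), on a carbonyl carbon. A cyclobutyl now sits on the carbonyl carbon whose other neighbour is the amide-type nitrogen in a ring. For the measured compounds named here, no measured pair shares such a change, so the size of the step in this assay is open. A limit at the start leaves room on one side only: compound 3 could stay at the limit or move to a measurable number, and a change beyond the usual scatter is not required. Compound 3 is expected to give about 8000 nM, with a range from 2000 nM to 30000 nM. This expectation means an estimated step of an at least 1.2-fold lower number from compound 2 to compound 3 (0.09 log units; that floor lies within the scatter).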

Compound 3, half-maximal inhibitory concentration: 1500 nM
Compound 3: the middle estimate sits 5.3-fold (0.73 log units) above what was measured, and the stated range ends above it.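

In this assay, putting cyclobutyl in place of the larger group with two carbon rings on the carbonyl carbon gives an at least 6.6-fold lower number from compound 2 to compound 3 (0.82 log units; beyond the scatter). For the compounds shown here, the result shows that this position responds to the group it carries: with the rest of the molecule unchanged, the change alone turns a compound held only by a limit into one with a measurable number, which the earlier compounds, differing in more than one place, could not show. Compound 2 has no exact number, so only the smallest possible size of the step is known: the limit of > 10000 nM in this assay, at which 1 of the 3 values shown sits.

Going by these compounds alone, only two groups have been compared here, so it stays open whether the drop in heavy atoms or the loss of the six-membered ring matters. A cyclopropyl, a straight butyl chain or a ring carrying an amine on this carbon would help tell these apart.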